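A few compounds are considered here, and "the series" means these few. Any claim that something is new, unique, unknown or untested is made for them only; others in the source may bear on it.

Of the compounds shown here, three have been measured in a functional assay on A549 cells (Homo sapiens) for inhibition, read by sulforhodamine B assay; a higher number here means a weaker inhibitor of growth, a lower number a stronger inhibitor of growth. Compound 2 `COc1ccc(-c2ccc(-c3ccc(-c4nc5cc(C)ccc5[nH]4)cc3)cc2)cc1OC` gives 2100 nM, compound 3 `COc1ccc(-c2ccc(-c3ccc(-c4nc5ccccc5[nH]4)cc3)cc2)cc1OC` gives 7600 nM, and compound 1 `c1ccc(-c2ccc(-c3ccc(-c4nc5ccccc5[nH]4)cc3)cc2)cc1` gives 41200 nM. The cores of compound 2 and compound 3 differ in one place, (methyl in place of hydrogen on an aromatic carbon), and that step is a 3.6-fold higher number from compound 2 to compound 3 (0.56 log units; beyond the scatter). Compound 3 and compound 1 differ by phenyl in place of 3,4-dimethoxyphenyl on an aromatic carbon, which gives a 5.4-fold higher number from compound 3 to compound 1 (0.73 log units; beyond the scatter).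

Compound 4 `Cc1ccc2[nH]c(-c3ccc(-c4ccc(-c5ccccc5)cc4)cc3)nc2c1` has not yet been measured. It differs from compound 2 by phenyl in place of 3,4-dimethoxyphenyl on an aromatic carbon, the same change seen between compound 3 and compound 1, at a place described in the same words. For compound 4 a step of similar size is expected, a 5.2-fold higher number from compound 2 to compound 4 (0.72 log units; beyond the scatter), because the same change gave a 5.4-fold higher number from compound 3 to compound 1 (0.73 log units; beyond the scatter). Compound 4 is therefore estimated at 11000 nM, most likely between 4500 nM and 28000 nM.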

Compound 4, concentration for 50% growth inhibition: 3630 nM
Compound 4: middle estimate off by 3.0-fold (0.48 log units), on the high side; the measured number lies below the stated range.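

On the core that carries the methyl, phenyl in place of 3,4-dimethoxyphenyl gives a 1.7-fold higher number from compound 2 to compound 4 (0.24 log units; within the scatter), so in this assay this change does not keep one size from core to core: the same change on two cores in this assay, a 5.4-fold higher number (0.73 log units; beyond the scatter) from compound 3 to compound 1 and a 1.7-fold higher number (0.24 log units; within the scatter) from compound 2 to compound 4, 3.1-fold (0.50 log units) apart, beyond the scatter of two such steps. Seen the other way, methyl in place of hydrogen gives an 11-fold lower number from compound 1 to compound 4 (1.05 log units; beyond the scatter), and this step also differs between the two cores: the same change on two cores in this assay, a 3.6-fold higher number (0.56 log units; beyond the scatter) from compound 2 to compound 3 and an 11-fold higher number (1.05 log units; beyond the scatter) from compound 4 to compound 1, 3.1-fold (0.50 log units) apart, beyond the scatter of two such steps. The two changes therefore do not simply add up across these four compounds, but four compounds cannot show why, or whether this holds for other groups.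

Still open, going by these compounds, is how a single methoxy group, an amine or a carboxylic acid would behave in place of the 3,4-dimethoxyphenyl's substituents. Also open, on these data alone, is whether chlorine in place of the methyl would show the same dependence on the core.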